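Working notes: propyl extension on the shared core

A few compounds are considered here, and "the series" means these few. Any claim that something is new, unique, unknown or untested is made for them only; others in the source may bear on it.

Measured compounds:
Compound 1 `Cc1cc(=O)oc2cc(OCc3nc(N)nc(Nc4cccc(O)c4)n3)ccc12`: "not determined" (no result reported)
Compound 2 `Cc1ccc(Nc2nc(N)nc(COc3ccc4ccc(=O)oc4c3)n2)cc1`: 1280 nM

For the measured compounds named here, in an assay on COS-7 cells for agonist activity at Free fatty acid receptor 1 (Homo sapiens), read by scintillation counting and inositol phosphate accumulation, with a stated time of 90 min (a lower number here means that less compound is needed, a higher number that more compound is needed for the effect), compound 2 gives 1280 nM; it is the only number in hand, as compound 1 carries no result. Compound 3 `CCCc1cc(=O)oc2cc(OCc3nc(N)nc(Nc4ccc(C)cc4)n3)ccc12` differs from compound 2 by propyl in place of hydrogen on an aromatic carbon. Going by the values given here, no measured pair shows this change, so the size of the step is open. A shift within or only slightly beyond the scatter is expected, in either direction, with a small gain judged marginally more likely; the expected step is a 1.4-fold lower number from compound 2 to compound 3 (0.15 log units; within the scatter). Compound 3 is estimated at 900 nM, with a range from 300 nM to 3000 nM.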

Compound 3, half-maximal effective concentration: 2900 nM
The estimate for compound 3 lay 3.2-fold (0.51 log units) below the measured number; the range from low to high includes it.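

In this assay, for the compounds shown here, propyl in place of hydrogen on an aromatic carbon, opposite the ring oxygen, gives a 2.3-fold higher number from compound 2 to compound 3 (0.36 log units; beyond the scatter) as the first readable step at this position. This position therefore tolerates propyl with a modest loss, and compound 3 still gives a measurable response. Nothing in hand accounts for this shift.

As far as these compounds go, whether a longer chain such as butyl would extend this loss remains open. From the compounds shown here alone, it is equally open whether an amine or a carboxylic acid at the same position would recover or lower the response.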